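A few compounds are considered here, and "the series" means these few. Any claim that something is new, unique, unknown or untested is made for them only; others in the source may bear on it.

Notes on the series. Compound 3 `COC(=O)/C=C/c1cccc(N(Cc2ccc(C(C)(C)C)cc2)C(=O)C2CCCCC2)c1` carries a 4-(tert-butyl)phenyl on a saturated chain carbon bound to an amide-type nitrogen. In an assay on isolated protein with Bile acid receptor (Homo sapiens) as the target (on this read-out lower numbers stand for an effect already at smaller amounts and higher numbers for an effect only at larger amounts of compound), compound 3 gives only a limit, > 1000 nM. Compound 1 `COC(=O)/C=C/c1cccc(N(Cc2ccccc2Br)C(=O)C2CCCCC2)c1`, with 2-bromophenyl at that carbon, likewise gives in this assay only a limit, > 1000 nM. Compound 2 `COC(=O)/C=C/c1cccc(N(Cc2cccc(Br)c2)C(=O)C2CCCCC2)c1`, with 3-bromophenyl there, also reaches only a limit, > 1000 nM. All three measured values thus sit at the limit of > 1000 nM in this assay, at which 3 of the 3 values shown sit, and the steps between them are a step that the two limits leave unreadable from compound 1 to compound 2, a step that the two limits leave unreadable from compound 1 to compound 3 and a step that the two limits leave unreadable from compound 2 to compound 3. None of them tells a size or a direction; no value in the series has so far been read as a number.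

Compound 4 `COC(=O)/C=C/c1cccc(N(Cc2cc(OC)cc(OC)c2)C(=O)C2CCCCC2)c1` has not yet been measured in this assay. It differs from compound 3 by 3,5-dimethoxyphenyl in place of 4-(tert-butyl)phenyl on a saturated chain carbon bound to an amide-type nitrogen. Among the compounds with values here, no measured step touches a 3,5-dimethoxyphenyl, and the three measured steps give no readable size at all, so nothing points to a gain past the limit. The step from compound 3 to compound 4 is therefore expected to be a step that the limit leaves unreadable from compound 3 to compound 4, nothing beyond the scatter. Compound 4 is estimated at 2500 nM, with a range from 700 nM to 10000 nM, and most probably again only a limit.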

Compound 4, half-maximal effective concentration: 606 nM
For compound 4 the middle estimate is 4.1-fold (0.62 log units) above the measured one; the measured number lies below the stated range.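

Within the data shown here, at the saturated chain carbon bound to an amide-type nitrogen, 3,5-dimethoxyphenyl yields the first value that reads as a number: in this assay compound 4 gives 606 nM. Measured against the three other groups at this carbon, the change gives an at least 1.6-fold lower number from compound 3 to compound 4 (0.21 log units; that floor lies within the scatter), an at least 1.6-fold lower number from compound 2 to compound 4 (0.21 log units; that floor lies within the scatter) and an at least 1.6-fold lower number from compound 1 to compound 4 (0.21 log units; that floor lies within the scatter). These are floors only, and the true sizes stay unread, as do the steps among compounds 1, 2 and 3, because the other end of each step is a limit and not a number: the limit of > 1000 nM in this assay, at which 3 of the 4 values shown sit.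

The leaving 4-(tert-butyl)phenyl and the entering 3,5-dimethoxyphenyl both hold 10 heavy atoms and differ in their 2 hydrogen-bond acceptors, but the compounds shown cannot tie the measured number to the oxygens or to the pattern of substitution, which a 3,5-dimethylphenyl or a 3-methoxyphenyl at this carbon would help to separate. Also open, as far as these compounds go, is whether the value of compound 4 holds with a carboxylic acid in place of the methyl ester on the shared core.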